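The source may hold more compounds than are shown below. What is called first, only, known or untested is meant among the compounds shown, and "the series" means these compounds.

Measured so far in a physicochemical assay for lipophilicity; on this read-out higher numbers stand for higher lipophilicity and lower numbers for lower lipophilicity:
- compound 1 `O=S(=O)(Nc1nccs1)c1ccc2c(c1)OCC[C@H]2c1ccc(C(F)(F)F)cc1-n1ccnn1`: 2.3
- compound 2 `O=S(=O)(Nc1nccs1)c1ccc2c(c1)OCC[C@@H]2c1ccc(C(F)(F)F)cc1-c1ccc(F)cn1`: 3.5
- compound 3 `O=S(=O)(Nc1nccs1)c1ccc2c(c1)OCC[C@@H]2c1ccc(C(F)(F)F)cc1-c1nccs1`: 3.3

Compound 3 lies within the scatter of compound 2 and beyond the scatter from compound 1, its furthest neighbour on these numbers. The next structure is compound 4 `O=S(=O)(Nc1nccs1)c1ccc2c(c1)OCC[C@@H]2c1ccc(C(F)(F)F)cc1-n1ccnn1`, with this change: 1H-1,2,3-triazol-1-yl in place of 1,3-thiazol-2-yl on an aromatic carbon. In words, 1H-1,2,3-triazol-1-yl stands in place of 1,3-thiazol-2-yl on an aromatic carbon.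

Within the data shown here, the one measured step at this place, a number 0.20 log units lower from compound 2 to compound 3 (within the scatter), is small, but it does not involve the incoming group, so it says little here. Compound 1 bears more directly. It carries the same 1H-1,2,3-triazol-1-yl group and is the mirror image of compound 4, differing only in the configuration of its single stereocentre. Mirror images are expected to read alike in this assay, so the value of compound 1, 2.3, sets the expectation. A drop beyond the scatter is therefore expected, a number 1.00 log units lower from compound 3 to compound 4 (beyond the scatter). For compound 4 the estimated value is 2.3, with an expected range from 2 to 2.6.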

Compound 4, distribution coefficient: 2.3
Compound 4: the middle estimate sits on the measured number at the digits printed; the range from low to high includes it.
By their numbers in this assay, from the lowest: compounds 1 and 4 (each within the scatter of the next); then compounds 3 and 2 (each within the scatter of the next).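

In this assay, this position responds to the group it carries: replacing 1,3-thiazol-2-yl with 1H-1,2,3-triazol-1-yl gives a number 1.00 log units lower from compound 3 to compound 4 (beyond the scatter), and replacing 5-fluoropyridin-2-yl with it gives a number 1.20 log units lower from compound 2 to compound 4 (beyond the scatter). Neither step resembles the earlier exchange between the two other groups, a number 0.20 log units lower from compound 2 to compound 3 (within the scatter), so 1H-1,2,3-triazol-1-yl is the only group shown here that stands apart on this read-out. The stereocentre does not separate the pair, with no change at the digits printed from compound 1 to compound 4 (within the scatter), and the comparison isolates configuration alone: the fact that compounds 1 and 4 differ only in the configuration as drawn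

Only these three groups are shown on this aromatic carbon, so the compounds do not establish how far the read-out can move at this position. As far as these compounds go, how an amine or a carboxylic acid here would compare with 1H-1,2,3-triazol-1-yl remains open.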